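Solubility notes: compound 1 and the defluoro analogue compound 4

The source may report more compounds than this note shows. Statements on the series, on what has been measured and on what is new or still open speak of the compounds shown alone.

Measured so far:
- compound 1, `CNC1(C)CN(c2c(F)cc3c(=O)c(C(=O)O)cn(C4CC4)c3c2F)C1`: 0.5 ug/mL
- compound 2, `CN[C@H]1CN(c2c(F)cc3c(=O)c(C(=O)O)cn(C4CC4)c3c2F)[C@@H]1C`: 13.1 ug/mL
- compound 3, `CC1(N)CN(c2c(F)cc3c(=O)c(C(=O)O)cn(C4CC4)c3c2F)C1`: 0.8 ug/mL; 15.3 ug/mL (2 entries)

In a physicochemical assay for solubility, at pH 7.4 (on this read-out lower numbers stand for lower solubility and higher numbers for higher solubility), compound 1 stands lowest of the two single numbers; the nearest is compound 2, reached by a 26-fold higher number from compound 1 to compound 2 (1.42 log units; beyond the scatter), which exchanges one four-membered ring bearing two nitrogen atoms for another on the same aromatic carbon. Compound 3 carries no single number, its repeat entries being (the several entries of compound 3 in this assay, 0.8 ug/mL; 15.3 ug/mL (2 entries)), which span more than the usual scatter and give no firm third point.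

Compound 4, `CNC1(C)CN(c2cc3c(cc2F)c(=O)c(C(=O)O)cn3C2CC2)C1`, is not yet measured. It differs from compound 1 by hydrogen in place of fluoro on an aromatic carbon, the site being ortho to the 3-methyl-3-(methylamino)azetidin-1-yl group and meta to the remaining fluoro group, on the fused aromatic ring of the shared core. None of the measured steps touches this fluoro: the only step shown, from compound 1 to compound 2, changes the azetidine instead. The loss of a single fluorine with no ring, donor or acceptor count change gives no basis for a step beyond the scatter, so compound 4 is expected to stay close to compound 1, with a 1.6-fold higher number from compound 1 to compound 4 (0.20 log units; within the scatter) as the estimated shift. The estimate for compound 4 in this assay is 0.8 ug/mL, within 0.25 ug/mL to 3 ug/mL.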

Compound 4, solubility: 0.7 ug/mL
Compound 4: the middle estimate sits 1.1-fold (0.06 log units) above what was measured, within the range that was stated.
By their numbers in this assay, from the lowest: compounds 1 and 4 (each within the scatter of the next); then compound 2.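

In this assay, among the compounds shown here, the first step at this aromatic carbon, ortho to the 3-methyl-3-(methylamino)azetidin-1-yl group, is hydrogen in place of fluoro: a 1.4-fold higher number from compound 1 to compound 4 (0.15 log units; within the scatter). For the compounds shown here, in this one pair the read-out does not separate fluoro from hydrogen at this site, whereas the only earlier step, a 26-fold higher number from compound 1 to compound 2 (1.42 log units; beyond the scatter), changed the azetidine and not this site. Going by these compounds alone, nothing measured so far gives a reason for this result.

From the compounds shown here alone, it remains open whether the same exchange would also stay within the scatter on the azetidine of compound 2, where the number is much higher. Also open, going by these compounds, is whether a larger group on this aromatic carbon, such as an amine or a methoxy group, would shift the number beyond the scatter on the core of compound 1.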